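A few compounds are considered here, and "the series" means these few. Any claim that something is new, unique, unknown or untested is made for them only; others in the source may bear on it.

Measured so far in a physicochemical assay for lipophilicity, measured as octanol-water partition, at pH 7.4; a lower number here means a more polar compound, a higher number a more lipophilic compound:
compound 1 `Cc1ccc2[nH]c(C(=O)N[C@H]3CCN(S(=O)(=O)N4CCCCC4)C[C@@H]3C(=O)NCCN(C)C)cc2c1` gives 2.3
compound 2 `O=C(N[C@H]1CN(S(=O)(=O)c2ccccc2)C[C@@H]1C(=O)N[C@H]1CCCNC1)c1cn(C2CC2)cn1` gives -0.7
compound 3 `O=C(N[C@H]1CN(S(=O)(=O)c2ccccc2)C[C@@H]1C(=O)N1C[C@H]2CCNC[C@H]21)c1cc(-c2ccccc2Cl)on1` gives 1.7

Compound 3 holds the middle place of these three numbers. Its distances to compound 1, the nearest, and to compound 2, the furthest, both lie beyond the scatter of repeated measurements.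

Compound 4 `CN(C(=O)[C@H]1CN(S(=O)(=O)c2ccccc2)C[C@@H]1NC(=O)c1cc(-c2ccccc2Cl)on1)[C@H]1CCCNC1` has not been measured yet. It differs from compound 3 in one place, on a carbonyl carbon, where the change is a group of 8 heavy atoms (6 carbon, 2 nitrogen; one six-membered non-aromatic ring with 1 hetero atom) in place of a group of 8 heavy atoms (6 carbon, 2 nitrogen; one four-membered non-aromatic ring with 1 hetero atom, one six-membered non-aromatic ring with 1 hetero atom), on a carbonyl carbon and nothing else is altered. The group that leaves has a four-membered non-aromatic ring that the group that enters lacks, yet the two match in heavy atoms and in hydrogen-bond donors and acceptors, and neither carries a net charge.

Among the compounds with values here, no two measured compounds differ in only one place, so no measured step shows what this kind of swap does in this assay here. The wide gap between compound 2 at -0.7 and compound 1 at 2.3 comes with differences in several places at once and cannot be pinned on one group. The best guide is therefore compound 3 at 1.7 and the close match of the two groups. The expected change is slightly downward, a number 0.20 log units lower from compound 3 to compound 4 (within the scatter) and no shift beyond the scatter is expected. For compound 4 the estimate is 1.5 with an expected range from 1 to 2 for most such measurements.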

Compound 4, distribution coefficient: 1.7
Estimate against measurement, compound 4: 0.20 log units below; measured number inside the range.
By their numbers in this assay, from the lowest: compound 2; then compounds 3 and 4 (each within the scatter of the next); then compound 1.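

In this assay, putting the group with one six-membered non-aromatic ring in place of the group that also carries a four-membered non-aromatic ring, on a carbonyl carbon whose other neighbour is a saturated ring carbon, gives no change at the digits printed from compound 3 to compound 4 (within the scatter). Within the data shown here, this is the first step in the set where only one place differs, so a single structural change can now be read on its own instead of being mixed with differences elsewhere in the molecule. It shows that, on this core, these two groups, which match in heavy atoms and in hydrogen-bond donors and acceptors, can differ in their rings and defined stereocentres without a shift beyond the scatter, although no measurement here offers an explanation for that outcome.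

Among these compounds, this single pair covers only two closely matched groups, so it remains open how far the number would move with a quite different group on this carbonyl carbon, such as a carboxylic acid or a morpholine. It also leaves open whether the same swap would behave alike on the cores of compound 1 or compound 2.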